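This account rests on a few compounds, and the source may have more. Where it says the series, first, only, none or still open, it means among the compounds named here.

Measured in an ADME assay on liver for metabolic stability, with Liver microsome (Rattus norvegicus) as the target, read by LC-MS, using microsomes, with a stated time of 5 h; a higher number here means faster removal of the compound, a lower number slower removal:

- compound 1 `C[C@]1(O)C[C@](c2cccc(OC(F)(F)F)c2)([C@H](O)c2ccccn2)C1` gives 50 mL/min/kg
- compound 2 `C[C@]1(O)C[C@](c2cccc(C(F)(F)F)c2)([C@H](O)c2ccccn2)C1` gives 66.7 mL/min/kg
- compound 3 `O[C@H](c1ccccn1)[C@]1(c2cccc(C(F)(F)F)c2)C[C@H](O)C1` gives 183 mL/min/kg

Compound 2 cannot be told apart from one measured neighbour but stands clearly apart from the other. The first step, a 1.3-fold higher number from compound 1 to compound 2 (0.13 log units; within the scatter), replaces trifluoromethoxy with trifluoromethyl on an aromatic carbon. The second, a 2.7-fold higher number from compound 2 to compound 3 (0.44 log units; beyond the scatter), puts hydrogen in place of methyl on a saturated ring carbon and is modest in size.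

Compound 4 `C[C@]1(O)C[C@@](c2cccc(C(F)(F)F)c2)([C@H](O)c2ccccn2)C1` comes next, and the change is the two compounds have the same atoms and bonds and differ only in configuration as drawn: 2 of 3 stereo elements differ; a stereocentre at a saturated ring carbon is drawn S in compound 2 and R in compound 4; a stereocentre at a saturated ring carbon is drawn r in compound 2 and s in compound 4. The two compounds have the same atoms and bonds and differ only in configuration as drawn. Neither measured step is a change of configuration alone, so neither offers a direct guide. The second step at least involves a saturated ring carbon, and it shows that a change in this part of the molecule can exceed the scatter. The data give no direction, so no shift beyond the scatter is expected, though the range must stay wide. The expected step is a 1.0-fold higher number from compound 2 to compound 4 (0.02 log units; within the scatter). The estimated value for compound 4 is 70 mL/min/kg, with an expected range from 30 mL/min/kg to 160 mL/min/kg.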

Compound 4, clearance: 317 mL/min/kg
Compound 4: the middle estimate sits 4.5-fold (0.66 log units) below what was measured; measured number above the stated range.
By their numbers in this assay, from the lowest: compounds 1 and 2 (each within the scatter of the next); then compounds 3 and 4 (each within the scatter of the next).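

In this assay, the new result is a 4.8-fold higher number from compound 2 to compound 4 (0.68 log units; beyond the scatter), and no group is exchanged to produce it. Each earlier step swapped one group for another, whereas this one shows that the spatial arrangement of the same atoms at these saturated ring carbons can, on its own, move clearance beyond the scatter. The arrangement can be held responsible for the step because nothing else separates the pair: the fact that compounds 2 and 4 differ only in the configuration as drawn

Both stereocentres change together, so the compounds shown cannot tell whether one of them alone accounts for the step. Also open, from the compounds shown here alone, is whether the same change of configuration would have a similar effect with trifluoromethoxy on the aromatic carbon, or with an amine or a carboxylic acid in place of trifluoromethyl.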